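Phenyl in Place of Methyl on a Cytotoxicity Read-out

The compounds below may be only part of what the source reports. "The series", "measured", "known", "first", "only" and "open" are said of these compounds alone.

Of the compounds shown here, two have been tested in a functional assay on THP-1 cells (Homo sapiens) for cytotoxicity, tested at 10 uM; on this read-out lower numbers stand for less inhibition and higher numbers for more inhibition at the one concentration tested (going by the name of the read-out). Compound 1, `O=c1[nH]c(=O)c2cc(CCCO)cnc2[nH]1`, gives 12% in this assay. Compound 2, `Cc1ccc(O)c(C(=O)c2ccc3onc(C)c3c2)c1`, gives 16% in this assay. These two numbers lie within the usual scatter of each other, so compound 2 does not stand apart from compound 1 on this read-out; both sit at the low end of the scale. For the measured compounds named here, no pair of measured compounds differs in a single place, so no measured step is available as a guide.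

Compound 3, `Cc1ccc(O)c(C(=O)c2ccc3onc(-c4ccccc4)c3c2)c1`, has not yet been measured. It differs from compound 2 in one place: phenyl in place of methyl on an aromatic carbon. The step of a number 6 percentage points higher from compound 2 to compound 3 (within the scatter) is expected to be small, at most modestly upward, and may well stay within the scatter. In this assay compound 3 is estimated to give about 22%, with a plausible range from 5% to 45%.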

Compound 3, a percentage reported as inhibition, at one concentration (the size of the read-out at that concentration, not a potency): 25%
Beside the measured number, compound 3's estimate is 3 percentage points below it, within the range that was stated.
By their numbers in this assay, from the lowest: compounds 1, 2 and 3 (each within the scatter of the next, the first and the last beyond it).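

In this assay, for the compounds shown here, the first step that can be read at a single place is a number 9 percentage points higher from compound 2 to compound 3 (within the scatter), for phenyl in place of methyl on an aromatic carbon next to the ring nitrogen. At this position, then, a single carbon can give way to six carbons in an aromatic ring with no step beyond the usual scatter, and both compounds remain low on the scale. No supporting measurement accompanies this step, so the data give no explanation for it.

Going by these compounds, whether an amine, a carboxylic acid or a longer chain on this same carbon would also stay within the scatter remains open. One step at one position also says nothing about changes elsewhere on the shared core.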